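The compounds below may be only part of what the source reports. "The series", "measured", "known", "first", "only" and "open" are said of these compounds alone.

Of the compounds shown here, three built on one shared core have been tested in a functional assay for inhibition of sodium/hydrogen exchanger (Oryctolagus cuniculus); a higher number here means a weaker inhibitor, a lower number a stronger inhibitor. Compound 1 `CCSc1cc(C)c(C(=O)N=C(N)N)cc1S(C)(=O)=O` gives 5.9 nM. Compound 2 `Cc1cc(OC(C)C)c(S(C)(=O)=O)cc1C(=O)N=C(N)N` gives 19 nM, and compound 3 `Cc1cc(OC2CCCCC2)c(S(C)(=O)=O)cc1C(=O)N=C(N)N` gives 37 nM. Compound 3 therefore carries the highest number of the three; the step of a 6.3-fold higher number from compound 1 to compound 3 (0.80 log units; beyond the scatter) lies beyond the scatter, whereas the step of a 1.9-fold higher number from compound 2 to compound 3 (0.29 log units; within the scatter) lies within it.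

Compound 4 `Cc1cc(N)c(S(C)(=O)=O)cc1C(=O)N=C(N)N` differs from compound 3 at a single spot: amino in place of cyclohexyloxy on an aromatic carbon. All three measured steps change the group on this same aromatic carbon, so all bear on it. The steps of a 3.2-fold higher number from compound 1 to compound 2 (0.51 log units; beyond the scatter) and a 6.3-fold higher number from compound 1 to compound 3 (0.80 log units; beyond the scatter) were modest, and the step of a 1.9-fold higher number from compound 2 to compound 3 (0.29 log units; within the scatter) was small. None of them introduces an amino group, so the direction for compound 4 is uncertain, and a modest step is expected, if any. The expected step is a 2.5-fold lower number from compound 3 to compound 4 (0.39 log units; beyond the scatter). Compound 4 is estimated at 15 nM, within a range from 4 nM to 60 nM.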

Compound 4, half-maximal inhibitory concentration: 16 nM
Compound 4: the middle estimate sits 1.1-fold (0.03 log units) below what was measured; the measured number falls inside the stated range.
By their numbers in this assay, from the lowest: compound 1; then compounds 4, 2 and 3 (each within the scatter of the next, the first and the last beyond it).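

Replacing cyclohexyloxy, with 7 heavy atoms, by amino, with 1 heavy atom and 1 hydrogen-bond donor, gives a 2.3-fold lower number from compound 3 to compound 4 (0.36 log units; beyond the scatter), so this position accepts a far smaller group that carries a donor without any loss in this assay. Amino and isopropoxy cannot be told apart, as a 1.2-fold lower number from compound 2 to compound 4 (0.07 log units; within the scatter) shows, while ethylsulfanyl keeps the strongest inhibition of the four, with a 2.7-fold higher number from compound 1 to compound 4 (0.43 log units; beyond the scatter). Size alone therefore does not order these groups, since ethylsulfanyl, which is larger than amino, gives a lower number, while cyclohexyloxy, also larger, gives a higher one.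

No measurement shown explains why these groups differ. From the compounds shown here alone, it remains open how a methylamino group, a dimethylamino group or a methylsulfanyl group on this aromatic carbon would compare with amino and ethylsulfanyl.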